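The compounds below may be only part of what the source reports. "The series", "measured", "known", "first", "only" and "open" are said of these compounds alone.

Measured compounds:
compound 1 `Cc1cc2c(c(N)nn2C)c(=O)[nH]1` — 5%
compound 2 `COC(=O)CCc1c(C)[nH]c(=O)c2c(N)nn(C)c12` — 5%

Both known compounds were tested in an assay on isolated protein for inhibition of serine/threonine-protein kinase D2 (Homo sapiens), read by mobility shift assay, tested at 30 uM; a lower number here means less inhibition, a higher number more inhibition at the concentration tested (going by the name of the read-out). Compound 1 gives 5%, and compound 2 gives 5%, so compound 1 stands level with compound 2 at the digits shown. Going by the values given here, the one recorded step, no change at the digits printed from compound 1 to compound 2 (within the scatter), placed 2-(methoxycarbonyl)ethyl in place of hydrogen on an aromatic carbon and moved nothing beyond the scatter.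

Compound 3 `Cc1cc2c(c(NS(C)(=O)=O)nn2C)c(=O)[nH]1` is not yet measured. It differs from compound 1 by methylsulfonyl in place of hydrogen on a nitrogen on an aromatic ring. Among the compounds with values here, no measured step touches this nitrogen, so the recorded change from compound 1 to compound 2 gives only a weak hint: the shared core has so far stayed near the bottom of the scale whatever was added. On that basis a step of a number 1 percentage points higher from compound 1 to compound 3 (within the scatter) is expected, that is, none beyond the scatter. Compound 3 is therefore estimated at 6%, with a range from -5% to 20%.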

Compound 3, a percentage reported as inhibition, at one concentration (the size of the read-out at that concentration, not a potency): 8%
Compound 3: middle estimate off by 2 percentage points, on the low side; low and high end bracket the measured number.
By their numbers in this assay, from the lowest: compounds 1, 2 and 3 (each within the scatter of the next).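

Going by these compounds alone, this is the first change at the amino nitrogen. In this assay, replacing amino with methanesulfonamido gives a number 3 percentage points higher from compound 1 to compound 3 (within the scatter). This nitrogen on an aromatic ring therefore accepts a methylsulfonyl group in place of hydrogen, but the change gives no measurable gain in inhibition at the concentration tested, and nothing measured here explains the result.

Still open, on these data alone, is whether a different group on this nitrogen, such as acetyl or the larger benzenesulfonyl, would move the read-out beyond the scatter. A single-concentration percentage also leaves open how compound 3 would behave at other concentrations, and whether a group such as a carboxylic acid on the shared core would change the picture.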